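A few compounds are considered here, and "the series" means these few. Any claim that something is new, unique, unknown or untested is made for them only; others in the source may bear on it.

Compound 1 `COc1cc(-c2cc(/C=C/C(=O)c3ccc(Cl)c(Cl)c3)[nH]n2)cc(OC)c1OC` stands at one end of the two numbers in hand, though not apart from the other: in a functional assay on RPMI-8226 cells (Homo sapiens) for cytotoxicity, read by sulforhodamine B assay, with a stated time of 48 h, tested at 0.01 uM (a lower number here means a stronger effect, a higher number a weaker effect of the compound at the concentration tested), compound 1 gives 100%, while compound 2 `COc1ccc(-c2cc(/C=C/C(=O)c3cc(OC)c(OC)c(OC)c3)[nH]n2)cc1OC` in this assay gives 97%, a number within the scatter of that of compound 1. Compound 3 `COc1cc(-c2cc(/C=C/C(=O)c3ccc(F)c(F)c3)[nH]n2)cc(OC)c1OC` has not been measured. It differs from compound 1 by 3,4-difluorophenyl in place of 3,4-dichlorophenyl on a carbonyl carbon. Going by the values given here, no step between measured compounds is recorded, so no change beyond the scatter is anticipated. Compound 3 is expected to give 98% in this assay, within a range of 85% to 106%. That corresponds to an expected step of a number 2 percentage points lower from compound 1 to compound 3 (within the scatter).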

Compound 3, a percentage reported as activity, at one concentration (the size of the read-out at that concentration, not a potency): 94%
Compound 3: middle estimate off by 4 percentage points, on the high side; the range from low to high includes it.
By their numbers in this assay, from the lowest: compounds 3, 2 and 1 (each within the scatter of the next).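

In this assay, going by these compounds alone, the exchange of 3,4-dichlorophenyl for 3,4-difluorophenyl on the carbonyl carbon amounts to a number 6 percentage points lower from compound 1 to compound 3 (within the scatter) and is the only single-place comparison available. At this concentration, the two halogenated phenyl groups therefore cannot be told apart at this position. No available evidence bears on why the exchange leaves the read-out within the scatter. Still open, from the compounds shown here alone, is whether an amine or a carboxylic acid on this phenyl ring would move the value in this assay beyond the scatter, and whether these two groups would separate at higher concentrations.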